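A few compounds are considered here, and "the series" means these few. Any claim that something is new, unique, unknown or untested is made for them only; others in the source may bear on it.

Compound 1: `O=C1c2ccc(OCc3cccc(-c4ccc(Cl)cc4F)c3)cc2CN1C1CCCC1`; in an assay on HEK293 cells for positive allosteric modulation of metabotropic glutamate receptor 2 (Rattus norvegicus), read by thallium flux (a higher number here means that more compound is needed for the effect, a lower number that less compound is needed), compound 1 gives > 5000 nM, which is a limit of the assay rather than a number.
Compound 2: `O=C1c2ccc(OCc3cccc(-c4ccc(C(F)(F)F)cc4F)c3)cc2CN1C1CCCC1`; in this assay compound 2 gives > 5000 nM, again a limit and not a number.
Compound 3: `O=C(O)c1cc(F)cc(-c2cccc(COc3ccc4c(c3)CN(C3CCCC3)C4=O)c2)c1`; in this assay compound 3 gives 130 nM.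

Among the measured compounds shown here, compound 3 therefore stands as the only compound with an actual number in this assay; the other two values sit at the limit of > 5000 nM in this assay, at which 2 of the 3 values shown sit. Compound 4, `O=C(O)c1ccc(-c2cccc(COc3ccc4c(c3)CN(C3CCCC3)C4=O)c2)c(Cl)c1`, differs from compound 3 by 4-carboxy-2-chlorophenyl in place of 3-carboxy-5-fluorophenyl on an aromatic carbon. For the measured compounds named here, two measured steps bear on this change: an at least 38-fold lower number from compound 1 to compound 3 (1.58 log units; beyond the scatter) and an at least 38-fold lower number from compound 2 to compound 3 (1.58 log units; beyond the scatter), both of which bring in the carboxy group that compound 4 keeps, while the step that the two limits leave unreadable from compound 1 to compound 2 yields nothing usable. Going by the values given here, because compound 3 gives 130 nM and compound 4 retains the carboxy group while only shifting its position and exchanging fluoro for chloro, no step as large as those two is expected; the shift from compound 3 to compound 4 is estimated as a 2.3-fold higher number from compound 3 to compound 4 (0.36 log units; beyond the scatter), a modest loss at most. For compound 4 the expected value is 300 nM, with a range from 80 nM to 2000 nM.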

Compound 4, half-maximal effective concentration: 110 nM
Beside the measured number, compound 4's estimate is 2.7-fold (0.44 log units) above it; measured number inside the range.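

In this assay, replacing 3-carboxy-5-fluorophenyl with 4-carboxy-2-chlorophenyl gives a 1.2-fold lower number from compound 3 to compound 4 (0.07 log units; within the scatter), so this position accepts both carboxy-bearing groups without a readable difference. The large gain over the groups without a carboxy substituent also appears with this second carboxy-bearing group, as an at least 45-fold lower number from compound 2 to compound 4 (1.65 log units; beyond the scatter) and an at least 45-fold lower number from compound 1 to compound 4 (1.65 log units; beyond the scatter), and among the four compounds shown only compound 3 and compound 4, the two with a carboxy group, give actual numbers. The values of compound 1 and compound 2 are limits of the assay, not numbers: the limit of > 5000 nM in this assay, at which 2 of the 4 values shown sit.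

On these data alone, it remains open whether the carboxylic acid itself is required or whether a tetrazole, a primary amide or a methyl ester could take its place. The step to compound 4 changes the carboxy position and the halogen together, and a plain 4-carboxyphenyl group would be needed to separate the two.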